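The compounds below may be only part of what the source reports. "The series", "measured", "known", "first", "only" and "open" are said of these compounds alone.

Measured in a functional assay on PANC-1 cells (Homo sapiens) for cytotoxicity, read by MTT assay, with a stated time of 24 h; on this read-out higher numbers stand for weaker inhibition and lower numbers for stronger inhibition:
- Compound 1 `C/C=C/C(=O)N1C(=O)C=CCC1/C=C/c1ccccc1`: 4200 nM
- Compound 2 `O=C1C=CCC(/C=C/c2ccccc2)N1C(=O)/C=C/c1ccccc1`: 16300 nM
- Compound 3 `C=CC(=O)N1C(=O)C=CCC1/C=C/c1ccccc1`: 8100 nM

Compound 2 stands apart from compound 1, but not from compound 3, as the numbers show a 2.0-fold lower number from compound 2 to compound 3 (0.30 log units; within the scatter). Compound 4 `O=C1C=CCC(/C=C/c2ccccc2)N1C(=O)/C=C/c1ccc(O)c(O)c1` differs from compound 2 in one place: 3,4-dihydroxyphenyl in place of phenyl on a double-bonded chain carbon bound to a double-bonded chain carbon. The change is 3,4-dihydroxyphenyl in place of phenyl. Going by the values given here, the only measured step at this place is modest, showing a 3.9-fold higher number from compound 1 to compound 2 (0.59 log units; beyond the scatter), and it swaps methyl for phenyl. Among the compounds with values here, no measured compound carries a substituted phenyl, so the evidence is indirect, and no step beyond the scatter is expected in this assay. The estimated step is a 1.4-fold lower number from compound 2 to compound 4 (0.13 log units; within the scatter). Compound 4 is expected at 12000 nM, with an estimated range of 4000 nM to 35000 nM.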

Compound 4, half-maximal inhibitory concentration: 5700 nM
For compound 4 the middle estimate is 2.1-fold (0.32 log units) above the measured one; the measured number falls inside the stated range.
By their numbers in this assay, from the lowest: compounds 1, 4, 3 and 2 (each within the scatter of the next, the first and the last beyond it).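

In this assay, the phenyl group at this place can be improved on: 3,4-dihydroxyphenyl in its place gives a 2.9-fold lower number from compound 2 to compound 4 (0.46 log units; beyond the scatter), so substitution on the ring matters here, not just the presence of a ring. Against methyl, the same group gives a 1.4-fold higher number from compound 1 to compound 4 (0.13 log units; within the scatter), so the gap seen with plain phenyl does not appear with this ring. Nothing available explains this difference. From the compounds shown here alone, whether methoxy or amine groups in place of these hydroxyl groups would give a similar number remains open.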